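The compounds below may be only part of what the source reports. "The series", "measured", "known", "first", "only" and "open" are said of these compounds alone.

Measured compounds and their numbers:

compound 1, `CCC(/C=C(\COC(C)=O)C(=O)c1ccccc1)CC`, in a functional assay on T47D cells (Homo sapiens) for inhibition, read by sulforhodamine B assay, with a stated time of 48 h (a higher number here means a weaker inhibitor of growth, a lower number a stronger inhibitor of growth), gives 89000 nM
compound 2, `C=C(C/C(=C\c1ccccc1)C(=O)c1ccccc1)C(=O)c1ccccc1`, in this assay gives 15000 nM
compound 3, `C=C(C/C(=C\c1ccc(Cl)cc1)C(=O)c1ccccc1)C(=O)c1ccccc1`, in this assay gives 19000 nM

Compound 3 sits second highest of the three numbers in this assay. Its nearest neighbour is compound 2, which differs from it only by a hydrogen where compound 3 carries a chloro group; the step of a 1.3-fold higher number from compound 2 to compound 3 (0.10 log units; within the scatter) is within the scatter, so the two cannot be told apart. Compound 1, built on a different core, stands well apart with the highest number.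

Compound 4, `C=C(C/C(=C\c1ccc(F)cc1)C(=O)c1ccccc1)C(=O)c1ccccc1`, is the next compound to be tested. It differs from compound 3 in one place: fluoro in place of chloro on an aromatic carbon. Going by the values given here, only one measured step touches this position, the exchange of hydrogen for chloro from compound 2 to compound 3, and it gave a change within the scatter. A second halogen at the same place is therefore expected to move the number little, if at all, and in no particular direction. The step from compound 3 to compound 4 is estimated as a 1.1-fold lower number from compound 3 to compound 4 (0.05 log units; within the scatter), within the scatter. Compound 4 is expected to give about 17000 nM, somewhere between 8000 nM and 36000 nM.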

Compound 4, concentration for 50% growth inhibition: 15000 nM
Compound 4: middle estimate off by 1.1-fold (0.05 log units), on the high side; the range from low to high includes it.
By their numbers in this assay, from the lowest: compounds 2, 4 and 3 (each within the scatter of the next); then compound 1.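

In this assay the exchange of chloro for fluoro on this aromatic carbon gives a 1.3-fold lower number from compound 3 to compound 4 (0.10 log units; within the scatter) and the exchange of hydrogen for fluoro gives no change at the digits printed from compound 2 to compound 4 (within the scatter) so neither halogen can be told apart from hydrogen here. Until now only chloro had been seen at this place, and a single exchange could have been a chance result; with fluoro added, compound 2, compound 3 and compound 4 form one group whose numbers cannot be separated, so the lack of any readable effect now rests on two different halogens instead of one. Nothing measured here bears on why this place tolerates these exchanges so evenly.

On these data alone, all three compounds carry only hydrogen or a single halogen atom at this place, so what a group built of several atoms would do there, such as an amine, a methoxy group or a carboxylic acid, remains open. Also open, as far as these compounds go, is whether the same holds for a group on another carbon of this ring or on the other aromatic rings of the shared core.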